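The source may hold more compounds than are shown below. What is called first, only, known or untested is meant among the compounds shown, and "the series" means these compounds.

Measured in an ADME assay on the whole organism (strain Sprague-Dawley) for pharmacokinetics, with Rattus norvegicus as the target, read by LC-MS, at a dose of 30 mg/kg by the oral route; a lower number here means that more of the compound stays in the plasma, a higher number that more of the compound sits outside the plasma:
- compound 1 `CC(C)(C)OC(=O)N[C@H]1CCCCC/C=C\[C@@H]2C[C@@]2(C(=O)NS(=O)(=O)C2CC2)NC(=O)[C@@H]2C[C@@H](OC(=O)N3CCc4ccccc4C3)CN2C1=O`: 5.98 L/kg
- compound 2 `CC(C)(C)OC(=O)N[C@H]1CCCCC/C=C\[C@@H]2C[C@@]2(C(=O)NS(=O)(=O)C2CC2)NC(=O)[C@@H]2C[C@@H](OC(=O)N3Cc4ccccc4C3)CN2C1=O`: 0.089 L/kg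

Of these two, compound 2 has the lower number, 0.089 L/kg, so more of it stays in the plasma. The next compound, compound 3 `CN(C)S(=O)(=O)NC(=O)[C@@]12C[C@H]1/C=C\CCCCC[C@H](NC(=O)OC(C)(C)C)C(=O)N1C[C@H](OC(=O)N3Cc4ccccc4C3)C[C@H]1C(=O)N2`, keeps everything in compound 2 except one group: dimethylamino in place of cyclopropyl on a sulfonyl sulfur. Put simply, cyclopropylsulfonyl becomes dimethylsulfamoyl, with dimethylamino in place of cyclopropyl on a sulfonyl sulfur.

For the measured compounds named here, only one measured step is available as a guide. That step, a 67-fold lower number from compound 1 to compound 2 (1.83 log units; beyond the scatter), is large, but it swaps a different group, on a carbonyl carbon. Going by the values given here, no measured pair changes the group on the sulfonyl sulfur, so the data give no direct evidence for the size or direction of this change. With no sign of a shift, the best starting point is a value close to that of compound 2. The expected change is a 1.3-fold higher number from compound 2 to compound 3 (0.13 log units; within the scatter), which would be no step beyond the usual scatter. Among the compounds with values here, the size of the one measured step, a 67-fold lower number from compound 1 to compound 2 (1.83 log units; beyond the scatter), shows that a single change can move this number far, so the range is kept wide. For compound 3 the estimated value is 0.12 L/kg, with an expected range of 0.04 L/kg to 0.45 L/kg.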

Compound 3, volume of distribution at steady state in the Rattus norvegicus assay: 2.58 L/kg
Compound 3: the middle estimate sits 22-fold (1.33 log units) below what was measured, and the stated range ends below it.
By their numbers in the Rattus norvegicus assay, from the lowest: compound 2; then compound 3; then compound 1.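

In the Rattus norvegicus assay, the group on the sulfonyl sulfur proves to be a sensitive spot: compound 2 gives 0.089 L/kg and compound 3 gives 2.58 L/kg, and dimethylamino in place of cyclopropyl gives a 29-fold higher number from compound 2 to compound 3 (1.46 log units; beyond the scatter), a large step, and it runs in the opposite direction to the earlier large step on the carbonyl carbon, a 67-fold lower number from compound 1 to compound 2 (1.83 log units; beyond the scatter). The heavy-atom count of the group stays the same in this swap, and neither group carries hydrogen-bond donors, acceptors or a net charge, so a large step here came with only the loss of the three-membered ring and a nitrogen taking the place of a carbon. For the compounds shown here, in a physicochemical assay for solubility, using the shake flask method, at pH 1.2 (a higher number here means a more soluble compound, a lower number a less soluble compound), compound 2 gives 0.5 ug/mL and compound 3 gives 0.5 ug/mL, and the same change gives no change at the digits printed from compound 2 to compound 3 (within the scatter), so the large step in the Rattus norvegicus assay has no counterpart in solubility at this pH.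

No measurement available here explains why the number rises. As far as these compounds go, it also remains open whether the loss of the ring or the entry of the nitrogen goes with the step, which a pyrrolidine ring or an isopropyl group on the same sulfonyl sulfur could help to separate.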